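The source may report more compounds than this note shows. Statements on the series, on what has been measured and on what is new or still open speak of the compounds shown alone.

Measured in a functional assay on K562 cells (Homo sapiens) for inhibition, read by CCK-8 assay, with a stated time of 72 h; a lower number here means a stronger inhibitor, a higher number a weaker inhibitor:
- compound 1 `O=C(/C=C/c1cccnc1)NCCCCCCCc1ccc(S(=O)(=O)Nc2ccccc2)cc1`: 56.5 nM
- compound 2 `O=C(/C=C/c1cccnc1)NCCCCCc1cccc(S(=O)(=O)Nc2ccccc2)c1`: 16.3 nM
- compound 3 `Cc1ccccc1NS(=O)(=O)c1cccc(CCCCCCNC(=O)/C=C/c2cccnc2)c1`: 0.456 nM

Compound 3 has the lowest number of the three and is the most potent in this assay, with both gaps beyond the scatter. Compound 4 `O=C(/C=C/c1cccnc1)NCCCCCCc1cccc(S(=O)(=O)Nc2ccc(C(F)(F)F)cc2)c1` has not yet been measured. It departs from compound 3 by one change: 4-(trifluoromethyl)phenyl in place of 2-methylphenyl on a sulfonamide nitrogen. In words, this is 4-(trifluoromethyl)phenyl in place of 2-methylphenyl on a sulfonamide nitrogen.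

For the measured compounds named here, no measured pair isolates a change at this place, so the expectation is loose. Compound 3 at 0.456 nM lies far below compound 2 at 16.3 nM, and matching so low a number with a new group is not the likeliest outcome. A moderate weakening beyond the scatter is expected, estimated as a 6.6-fold higher number from compound 3 to compound 4 (0.82 log units; beyond the scatter). For compound 4 the estimated value is 3 nM, with an expected range of 0.4 nM to 25 nM.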

Compound 4, half-maximal inhibitory concentration: 44.9 nM
Compound 4: the middle estimate sits 15-fold (1.18 log units) below what was measured, and the stated range ends below it.
By their numbers in this assay, from the lowest: compound 3; then compound 2; then compounds 4 and 1 (each within the scatter of the next).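

In this assay, for the compounds shown here, the step from 2-methylphenyl to 4-(trifluoromethyl)phenyl on the sulfonamide nitrogen is the only change here isolated by a matched pair, and it gives a 98-fold higher number from compound 3 to compound 4 (1.99 log units; beyond the scatter). The group on this nitrogen is therefore no passive passenger: with the rest of the structure held constant, this one exchange costs most of the potency of compound 3 at 0.456 nM. Nothing measured here accounts for the loss.

The exchange alters both the substituent and its place on the phenyl ring, so the two contributions cannot be separated; 4-methylphenyl and 2-(trifluoromethyl)phenyl would pull them apart. From the compounds shown here alone, whether the methyl group of compound 3 contributes at all also stays open, and an unsubstituted phenyl on the same chain would address that.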